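Branching the amide on a very tight melatonin ligand

The source may hold more compounds than are shown below. What is called first, only, known or untested is meant among the compounds shown, and "the series" means these compounds.

Measured compounds: compound 1 `COc1cccc(Nc2ccc(NC(=O)C3CC3)cc2)c1`, 61 nM; compound 2 `COc1cccc(N(C)c2ccc(NC(C)=O)cc2)c1`, 0.05 nM.

In an assay on isolated protein for binding affinity to melatonin receptor type 1A (Homo sapiens) (a lower number here means a stronger inhibitor, a higher number a weaker inhibitor), compound 2 gives 0.05 nM, the lowest of the two numbers shown, and compound 1 gives a far higher number, 61 nM. Compound 3 `COc1cccc(N(C)c2ccc(NC(=O)C(C)C)cc2)c1` differs from compound 2 in one place: isopropyl in place of methyl on a carbonyl carbon. Going by the values given here, no measured pair tells how large such a change is here, so he expects only a modest step in this assay, at most a slight loss, possibly none beyond the scatter. His estimate for compound 3 is 0.12 nM, ranging from 0.02 nM to 0.7 nM, a step of a 2.4-fold higher number from compound 2 to compound 3 (0.38 log units; beyond the scatter).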

Compound 3, inhibition constant: 106 nM
Compound 3: middle estimate off by 880-fold (2.95 log units), on the low side; measured number above the stated range.
By their numbers in this assay, from the lowest: compound 2; then compounds 1 and 3 (each within the scatter of the next).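

In this assay, isopropyl in place of methyl on a carbonyl carbon gives a 2100-fold higher number from compound 2 to compound 3 (3.33 log units; beyond the scatter), so in this pair the acetyl position tolerates this branched group very poorly. The change from acetyl to isopropylcarbonyl adds only carbon, with no ring, no hydrogen-bond donor or acceptor and no net charge, yet the step is large. Nothing shown bears on why it is so large. The compounds shown leave open whether ethyl on the same carbonyl carbon already brings a loss, and whether a straight propyl chain behaves like isopropyl.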